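The source may hold more compounds than are shown below. What is called first, only, known or untested is meant among the compounds shown, and "the series" means these compounds.

Among the measured compounds shown here, compound 2 `COc1ccc([C@H]2CC(C)(O)[C@@H]3CC[C@@H](C)C[C@H]3O2)cc1O` is one of three compounds measured in an ADME assay on MDCK cells (Canis lupus familiaris) for cytotoxicity, read by MTT assay, with a stated time of 48 h (a higher number here means that more compound is tolerated, a lower number that less compound is tolerated), where compound 2 gives 738000 nM. Compound 1 `COc1ccc([C@H]2CC(C)(O)[C@@H]3CC[C@@H](C)C[C@H]3O2)cc1OC` reaches only the limit of > 937000 nM in this assay. Compound 3 `C[C@@H]1CC[C@@H]2[C@@H](C1)O[C@@H](c1ccccc1O)CC2(C)F` gives 44000 nM in this assay, so compound 2 stands highest of the two plain numbers. For the measured compounds named here, the one measured single-point step, an at least 1.2-fold lower number from compound 1 to compound 2 (0.10 log units; that floor lies within the scatter), alters an aromatic substituent and does not touch the saturated ring carbon. Compound 4 `COc1ccc([C@H]2CC(C)(F)[C@@H]3CC[C@@H](C)C[C@H]3O2)cc1O` differs from compound 2 by fluoro in place of hydroxy on a saturated ring carbon. Going by the values given here, no measured step covers this change; compound 3 carries a fluoro on that saturated ring carbon together with a different aromatic ring, and its number sits well below that of compound 2. Compound 4 is therefore expected to give a lower number, a 6.2-fold lower number from compound 2 to compound 4 (0.79 log units; beyond the scatter), with an estimate of 120000 nM between 30000 nM and 450000 nM.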

Compound 4, half-maximal cytotoxic concentration: 136000 nM
Beside the measured number, compound 4's estimate is 1.1-fold (0.05 log units) below it, and the stated range covers the measured number.
By their numbers in this assay, from the lowest: compound 3; then compound 4; then compound 2. At a limit, above all of these: compound 1.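

Fluoro in place of hydroxy on a saturated ring carbon gives a 5.4-fold lower number from compound 2 to compound 4 (0.73 log units; beyond the scatter), in this assay. Compound 3 had carried that fluoro only together with a different aromatic ring, whereas here the change stands alone and the rest of the structure stays the same. Compound 1 holds a limit rather than a number, so the only earlier step could not be read in full: the limit of > 937000 nM in this assay, at which 1 of the 4 values shown sits.

The compounds shown leave open whether the lower number follows the loss of hydroxy or the arrival of fluoro. They also leave open how an amine or a plain hydrogen on that saturated ring carbon would read.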